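A few compounds are considered here, and "the series" means these few. Any claim that something is new, unique, unknown or untested is made for them only; others in the source may bear on it.

Measured compounds:
compound 1, `COc1ccc([C@@H]2C/C(=N/OCc3cn(-c4ccccc4CO)nn3)c3cc(CC=C(C)C)c(OC)cc3O2)cc1`, gives 100%;
compound 2, `COc1cc2c(cc1CC=C(C)C)C(=O)C[C@@H](c1ccc(Oc3ccc(F)cc3)cc1)O2`, gives 29%;
compound 3, `C#CCO/N=C1/C[C@@H](c2ccc(OC)cc2)Oc2cc(OC)c(CC=C(C)C)cc21`, gives 65%.

All three numbers come from a functional assay on HCT-116 cells (Homo sapiens) for inhibition, read by sulforhodamine B assay, with a stated time of 48 h, tested at 50 uM; a lower number here means less inhibition of growth, a higher number more inhibition of growth at the concentration tested. Compound 1 stands highest of the three, with compound 3 the nearest of the two others and compound 2 the furthest, both gaps lying beyond the usual scatter. Among the compounds with values here, no single-point step between measured compounds is available, so the account can only say what these three values show.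

The unmeasured compound 4, `COc1ccc([C@@H]2C/C(=N/OCc3cn(-c4cc(OC)c(OC)c(OC)c4)nn3)c3cc(CC=C(C)C)c(OC)cc3O2)cc1`, differs from compound 1 in one place: 3,4,5-trimethoxyphenyl in place of 2-(hydroxymethyl)phenyl on an aromatic nitrogen. Without a measured step of this kind, the writer expects at most a modest change in this assay, more likely downward than upward, since compound 1 already sits at the top of what this assay reports and cannot rise further. The writer's estimate for compound 4 is 85%, within a range of 55% to 100%, which means an expected step of a number 15 percentage points lower from compound 1 to compound 4 (beyond the scatter).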

Compound 4, percent growth inhibition at one concentration: 29%
Estimate against measurement, compound 4: 56 percentage points above, and the stated range ends above it.
By their numbers in this assay, from the lowest: compounds 2 and 4 (each within the scatter of the next); then compound 3; then compound 1.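

In this assay the group on the aromatic nitrogen of the five-membered ring turns out to matter: 3,4,5-trimethoxyphenyl in place of 2-(hydroxymethyl)phenyl brings a number 71 percentage points lower from compound 1 to compound 4 (beyond the scatter) while the rest of the structure stays the same. Within the data shown here, the earlier compounds offered no comparison in one place, so this is the first sign that growth inhibition at the tested concentration depends on what this aromatic ring carries. The change removes a hydroxymethyl group and adds three methoxy groups at once, and no measurement at hand says which of these accounts for the fall.

The compounds shown leave open what an unsubstituted phenyl, or a phenyl bearing an amine or a carboxylic acid in place of hydroxymethyl, would give on this nitrogen. They also leave open whether the step would hold at lower concentrations.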